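One Extra Methyl on a Potent Compound

The source may hold more compounds than are shown below. What is called first, only, known or untested is meant among the compounds shown, and "the series" means these compounds.

In a functional assay on NCI-H460 cells (Homo sapiens) for cytotoxicity, read by MTT assay, with a stated time of 96 h (a lower number here means a stronger inhibitor, a higher number a weaker inhibitor), compound 1 (`COc1ncc(-c2cc(OC3CCOCC3)c3nc(N)nc(C)c3c2)cc1F`) gives 1100 nM while compound 2 (`CNc1nc(C)c2cc(-c3cnc(OC)c(NS(=O)(=O)c4ccc(F)cc4F)c3)cc(OC3CCOCC3)c2n1`) gives 59 nM (the lower of the two numbers, and a gap beyond the usual scatter). Compound 3 (`COc1ncc(-c2cc(OC3CCOCC3)c3nc(N(C)C)nc(C)c3c2)cc1NS(=O)(=O)c1ccc(F)cc1F`) differs from compound 2 in one place (methyl in place of hydrogen on a nitrogen on an aromatic ring): methyl in place of hydrogen on a nitrogen on an aromatic ring, so methylamino becomes dimethylamino. Within the data shown here, no measured pair shows this change, so any forecast is uncertain. A modest weakening in this assay is expected, estimated as a 2.5-fold higher number from compound 2 to compound 3 (0.41 log units; beyond the scatter) (a rough figure). Compound 3 is estimated at 150 nM (range 40 nM to 600 nM).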

Compound 3, half-maximal inhibitory concentration: 4300 nM
Compound 3: the middle estimate sits 29-fold (1.46 log units) below what was measured; the whole stated range lies below it.
By their numbers in this assay, from the lowest: compound 2; then compound 1; then compound 3.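

In this assay, the hydrogen on this nitrogen turns out to matter a great deal: swapping it for methyl, a change of one carbon, gives a 73-fold higher number from compound 2 to compound 3 (1.86 log units; beyond the scatter) and so makes a large difference. Methylamino to dimethylamino is therefore no small edit at this position, although nothing available here explains the weakening.

Still open, on these data alone, is how a larger group on this nitrogen, such as ethyl or a longer chain, would behave. Compound 1 differs from compound 2 in more than one place, so the effect of the first methyl on this nitrogen cannot be read.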